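The source may hold more compounds than are shown below. What is called first, only, known or untested is meant among the compounds shown, and "the series" means these compounds.

Measured compounds:
Compound 1, `O=C1C=C(Nc2ccccc2)C(=O)c2c1nc1n2[C@H]2OC[C@@H](O)[C@H]2OC1`: 5620 nM
Compound 2, `CCCc1ccc(NC2=CC(=O)c3nc4n(c3C2=O)[C@H]2OC[C@@H](O)[C@H]2OC4)cc1`: 4990 nM
Compound 3, `CCOc1ccccc1NC1=CC(=O)c2nc3n(c2C1=O)[C@H]1OC[C@@H](O)[C@H]1OC3`: 6040 nM

All three numbers come from a functional assay on HeLa cells (Homo sapiens) for inhibition, read by sulforhodamine B assay; a higher number here means a weaker inhibitor, a lower number a stronger inhibitor. Compound 1 stands second highest of the three; its nearest neighbour is compound 3, with a 1.1-fold higher number from compound 1 to compound 3 (0.03 log units; within the scatter), and its furthest is compound 2, with a 1.1-fold lower number from compound 1 to compound 2 (0.05 log units; within the scatter). The remaining step, a 1.2-fold higher number from compound 2 to compound 3 (0.08 log units; within the scatter), is likewise within the scatter, so the three substituent patterns on the anilino ring are indistinguishable here.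

Compound 4, `O=C1C=C(N2CCCC2)C(=O)c2c1nc1n2[C@H]2OC[C@@H](O)[C@H]2OC1`, differs from compound 1 in one place: pyrrolidin-1-yl in place of anilino on a double-bonded ring carbon. Among the measured compounds shown here, no measured step tests this change; the three steps alter only substituents on the anilino ring, and none moved the number beyond the scatter. On these data alone, removing the aromatic ring and the hydrogen-bond donor is untested, so a step of a 1.6-fold higher number from compound 1 to compound 4 (0.20 log units; within the scatter) is expected only with wide uncertainty, leaning weaker. Compound 4 is estimated at 9000 nM, between 2500 nM and 30000 nM.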

Compound 4, half-maximal inhibitory concentration: > 16000 nM
Compound 4 gave a limit, no number; the forecaster's own chance of this, stated with the estimate: 20%; middle value at least 1.7-fold (0.24 log units) away from the limit.
By their numbers in this assay, from the lowest: compounds 2, 1 and 3 (each within the scatter of the next). At a limit, above all of these: compound 4.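

Compound 4 gives no number in this assay, only a limit: the limit of > 16000 nM in this assay, at which 1 of the 4 values shown sits. Whereas the changes on the anilino ring all stayed within the scatter, pyrrolidin-1-yl in place of anilino on this double-bonded ring carbon gives an at least 2.8-fold higher number from compound 1 to compound 4 (0.45 log units; beyond the scatter), so the group at this position does matter. This one change removes the aromatic ring and the hydrogen-bond donor together, and the step cannot tell these apart.

The compounds shown leave open how cyclohexylamino, which drops only the aromatic ring, or N-methylanilino, which drops only the amine hydrogen, would read at this carbon.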